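A few compounds are considered here, and "the series" means these few. Any claim that something is new, unique, unknown or untested is made for them only; others in the source may bear on it.

Of the compounds shown here, two sharing one core have been tested in an assay on isolated protein for inhibition of 2-Hydroxyacid oxidase 2 (Homo sapiens), tested at 1 uM; on this read-out higher numbers stand for a stronger effect at the one concentration tested and lower numbers for a weaker effect. Compound 1 `Cc1n[nH]c(C(=O)O)c1Cc1cccc(-c2ccc(OC(F)(F)F)cc2)c1` gives 6%. Compound 2 `Cc1n[nH]c(C(=O)O)c1Cc1cccc(-c2ccc(C#N)cc2)c1` gives 13%, the higher of the two numbers, though the gap to compound 1 is within the scatter of this measurement, so the two cannot be told apart with confidence. For the measured compounds named here, the only measured step, a number 7 percentage points higher from compound 1 to compound 2 (within the scatter), therefore shows that swapping the group at this position has not moved the read-out beyond noise.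

Compound 3 `Cc1n[nH]c(C(=O)O)c1Cc1cccc(-c2ccc(C(N)=O)cc2)c1` differs from compound 2 in one place: carbamoyl in place of cyano on an aromatic carbon. Going by the values given here, no measured step involves carbamoyl, and the one step that does touch this position, from compound 1 to compound 2, stayed within the scatter. On that basis compound 3 is expected to show a step of a number 1 percentage points lower from compound 2 to compound 3 (within the scatter), which means no change beyond the scatter. Compound 3 is estimated at 12%, with a range from 0% to 30%.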

Compound 3, a percentage reported as inhibition, at one concentration (the size of the read-out at that concentration, not a potency): 18%
The estimate for compound 3 lay 6 percentage points below the measured number; the range from low to high includes it.
By their numbers in this assay, from the lowest: compounds 1, 2 and 3 (each within the scatter of the next, the first and the last beyond it).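

In this assay, for the compounds shown here, carbamoyl in place of trifluoromethoxy gives a number 12 percentage points higher from compound 1 to compound 3 (beyond the scatter), the first step at this position to clear the scatter. Carbamoyl in place of cyano gives a number 5 percentage points higher from compound 2 to compound 3 (within the scatter), so these two groups cannot be told apart, just as cyano could not be told apart from trifluoromethoxy. Going by these compounds alone, the group on this aromatic carbon can therefore change the read-out, but the only change beyond the scatter so far is a small one, seen between the two ends of this short series.

Nothing available explains why carbamoyl and trifluoromethoxy give different numbers. On these data alone, it also remains open whether a different group at this place, such as an amine, a carboxylic acid or a longer chain, would raise the number further or lower it.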